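The source may report more compounds than this note shows. Statements on the series, on what has been measured and on what is new or still open speak of the compounds shown alone.

Three compounds have been measured in an assay on isolated protein for antagonist activity at Bile acid receptor (Homo sapiens), read by TR-FRET and LanthaScreen; a lower number here means a stronger inhibitor, a higher number a weaker inhibitor:

compound 1, `CC(=O)N1CCC(C[C@@H](c2nc3ccccc3n2C)N2C(=O)CN(c3ccc(Oc4ccccc4)cc3)C2=O)CC1`, gives 740 nM
compound 2, `CC(=O)N1CCC(C[C@@H](c2nc3cc(F)ccc3n2C)N2C(=O)CN(c3ccc(Oc4ccccc4)cc3)C2=O)CC1`, gives 8300 nM
compound 3, `CC(=O)N1CCC(C[C@@H](c2nc3ccc(Cl)cc3n2C)N2C(=O)CN(c3ccc(Oc4ccccc4)cc3)C2=O)CC1`, gives 3500 nM

Compound 3 stands second highest of the three numbers in this assay. Its nearest neighbour is compound 2, separated by a 2.4-fold lower number from compound 2 to compound 3 (0.38 log units; beyond the scatter); its furthest is compound 1, separated by a 4.7-fold higher number from compound 1 to compound 3 (0.67 log units; beyond the scatter).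

Compound 4, `CC(C)C(=O)N1CCC(C[C@@H](c2nc3ccc(Cl)cc3n2C)N2C(=O)CN(c3ccc(Oc4ccccc4)cc3)C2=O)CC1`, differs from compound 3 in one place: isopropyl in place of methyl on a carbonyl carbon. All three measured steps concern a different part of the molecule: an 11-fold higher number from compound 1 to compound 2 (1.05 log units; beyond the scatter) and a 4.7-fold higher number from compound 1 to compound 3 (0.67 log units; beyond the scatter) each put a halogen onto an aromatic carbon of the shared core, and a 2.4-fold lower number from compound 2 to compound 3 (0.38 log units; beyond the scatter) compares the two halogenated cores. None of them touches the acetyl group on the piperidine nitrogen, so nothing measured here speaks to the change from methyl to isopropyl on that carbonyl carbon.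

Without a bearing step, the expectation for compound 4 is a number close to that of compound 3, with no direction favoured and a step expected to stay within the scatter, no change at the digits printed from compound 3 to compound 4 (within the scatter). Compound 4 is therefore estimated at 3500 nM in this assay, expected to lie between 1200 nM and 10000 nM.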

Compound 4, half-maximal inhibitory concentration: 130 nM
Beside the measured number, compound 4's estimate is 27-fold (1.43 log units) above it; the measured number lies below the stated range.
By their numbers in this assay, from the lowest: compound 4; then compound 1; then compound 3; then compound 2.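

In this assay, going by these compounds alone, the acyl group on the piperidine nitrogen proves to be a sensitive position, which the earlier steps on the shared core could not reveal: isopropyl in place of methyl on a carbonyl carbon gives a 27-fold lower number from compound 3 to compound 4 (1.43 log units; beyond the scatter). This step exceeds either halogen step on the core, although the change adds carbon alone, with no ring, hydrogen-bond donor, hydrogen-bond acceptor or net charge on either side. Within the data shown here, nothing available explains why this change moves the number so far.

Isopropyl is shown on one core only, that of compound 3, so it remains open whether the same step would hold on the cores of compound 1 and compound 2. Also open, as far as these compounds go, is how a tert-butyl group, a cyclopropyl ring, a longer chain or an amine would compare with isopropyl on this carbonyl carbon.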